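A few compounds are considered here, and "the series" means these few. Any claim that something is new, unique, unknown or untested is made for them only; others in the source may bear on it.

Working notes on the series. Compound 1 `COc1cc(-c2ccc3c(c2)oc(=O)n3Cc2ccc(F)cc2)cnc1N` gives 36400 nM in a functional assay on HCT-116 cells (Homo sapiens) for inhibition, read by MTT assay, with a stated time of 72 h; a higher number here means a weaker inhibitor, a lower number a stronger inhibitor. Compound 2 `N#Cc1cc(-c2ccc3c(c2)oc(=O)n3Cc2ccc(F)cc2)cnc1N` gives 8250 nM in this assay, and compound 3 `Nc1ccc(-c2ccc3c(c2)oc(=O)n3Cc2ccc(F)cc2)cn1` gives 16500 nM in this assay. Among the three numbers compound 3 stands second highest: toward compound 2 the step is a 2.0-fold higher number from compound 2 to compound 3 (0.30 log units; within the scatter), which stays within the scatter, while the step of a 2.2-fold lower number from compound 1 to compound 3 (0.34 log units; beyond the scatter) lies beyond it. The remaining measured step, a 4.4-fold lower number from compound 1 to compound 2 (0.64 log units; beyond the scatter), is likewise modest. All three measured steps exchange one substituent on the six-membered aromatic ring attached to the shared core; none touches the ring itself.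

Compound 4 `O=c1oc2cc(-c3cnc4[nH]ccc4c3)ccc2n1Cc1ccc(F)cc1` changes that ring: a group of 9 heavy atoms (7 carbon, 2 nitrogen; one five-membered aromatic ring with 1 hetero atom, one six-membered aromatic ring with 1 hetero atom) in place of a group of 7 heavy atoms (5 carbon, 2 nitrogen; one six-membered aromatic ring with 1 hetero atom), on an aromatic carbon. Within the data shown here, no measured step bears directly on a change of this kind, so the measured steps only set the scale of what single changes on this part of the molecule have done so far, and that scale is modest in both directions. The expectation for compound 4 in this assay is therefore a step close to the scatter, with no direction fixed by the data. The estimate for compound 4 is 12000 nM, with a range from 3000 nM to 45000 nM, which is expected to mean a 1.4-fold lower number from compound 3 to compound 4 (0.14 log units; within the scatter).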

Compound 4, half-maximal inhibitory concentration: 5990 nM
Compound 4: the middle estimate sits 2.0-fold (0.30 log units) above what was measured, and the stated range covers the measured number.
By their numbers in this assay, from the lowest: compounds 4, 2 and 3 (each within the scatter of the next, the first and the last beyond it); then compound 1.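

Exchanging the whole 6-aminopyridin-3-yl group for the fused two-ring group in this assay gives a 2.8-fold lower number from compound 3 to compound 4 (0.44 log units; beyond the scatter), so this position accepts a change of the ring itself and not only of a substituent on it, and the size of the step remains modest. The comparison with the nitrile-bearing group gives a 1.4-fold lower number from compound 2 to compound 4 (0.14 log units; within the scatter), which leaves the two compounds undistinguished, whereas the comparison with the methoxy-bearing group gives a 6.1-fold lower number from compound 1 to compound 4 (0.78 log units; beyond the scatter), the widest step among the four compounds, though still a modest one. Nothing at hand explains any of these steps, and the contribution of the second ring cannot be separated from the loss of the amino group.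

From the compounds shown here alone, whether the fused group can carry a further substituent remains open, for example a methyl group, a morpholine or a carboxylic acid, and so does whether any such group would move the number beyond the scatter of compound 2 as well as that of compound 3. Going by these compounds, all four compounds also share the rest of the molecule, so the response of this assay to a change elsewhere on the shared core remains unknown.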